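The compounds below may be only part of what the source reports. "The series", "measured", "known", "first", "only" and "open" are said of these compounds alone.

Measured in a functional assay on PC-3 cells (Homo sapiens) for cytotoxicity, read by MTT assay, with a stated time of 48 h; on this read-out higher numbers stand for weaker inhibition and lower numbers for stronger inhibition:
compound 1 `Cc1ccc(Cn2c(/C=C3\SC(=S)N(CC(=O)O)C3=O)nc3cc(F)ccc32)cc1` gives 10200 nM
compound 2 `Cc1ccc(Cn2c(/C=C3\SC(=S)N(CC(=O)O)C3=O)nc3ccc(F)cc32)cc1` gives 5820 nM
compound 3 `COc1ccc2c(c1)nc(/C=C1\SC(=S)N(CC(=O)O)C1=O)n2Cc1ccc(C)cc1` gives 3640 nM

Compound 1 and compound 2 have the same atoms joined differently; the difference between the two cores is not broken down here. Compound 3 arises from compound 1 by methoxy in place of fluoro on an aromatic carbon, and the step was a 2.8-fold lower number from compound 1 to compound 3 (0.45 log units; beyond the scatter). Compound 4 `COc1ccc2nc(/C=C3\SC(=S)N(CC(=O)O)C3=O)n(Cc3ccc(C)cc3)c2c1` is not yet measured; it arises from compound 2 by methoxy in place of fluoro on an aromatic carbon. The place of the change reads the same in both pairs, so this is the same change carried onto the core of compound 2. In this assay compound 2 and compound 3 lie within the scatter of each other. For the measured compounds named here, the only guide is the single earlier step, a 2.8-fold lower number from compound 1 to compound 3 (0.45 log units; beyond the scatter), so the expectation is wide. For compound 4 a step of a 2.2-fold lower number from compound 2 to compound 4 (0.33 log units; beyond the scatter) in this assay is expected. Compound 4 is estimated at 2700 nM, with a range from 1200 nM to 6500 nM.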

Compound 4, half-maximal inhibitory concentration: 16200 nM
Beside the measured number, compound 4's estimate is 6.0-fold (0.78 log units) below it; the measured number lies above the stated range.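

In this assay methoxy in place of fluoro on an aromatic carbon gives a 2.8-fold higher number from compound 2 to compound 4 (0.44 log units; beyond the scatter) on the core of compound 2. The change does not carry from one core to the other, and its direction reverses: the same change on two cores in this assay, a 2.8-fold lower number (0.45 log units; beyond the scatter) from compound 1 to compound 3 and a 2.8-fold higher number (0.44 log units; beyond the scatter) from compound 2 to compound 4, 7.8-fold (0.89 log units) apart, beyond the scatter of two such steps. For the compounds shown here, this shows that the result of the change depends on the core, but it rests on only two pairs and does not show why the cores differ.

As far as these compounds go, whether a group such as an amine or chloro in place of fluoro would also move in opposite directions on the two cores remains open. So does whether the reversal holds on any further core.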